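The compounds below may be only part of what the source reports. "The series", "measured", "known", "first", "only" and "open" are said of these compounds alone.

Three compounds have numbers in an assay on cells for inhibition of Palmitoleoyl-protein carboxylesterase NOTUM variant C330S (Homo sapiens), read by fluorescence, with a stated time of 40 min; a higher number here means a weaker inhibitor, a lower number a stronger inhibitor. Compound 1 `Cc1cc(C(=O)O)c(C)n1-c1cccc(C(C)C)c1` gives 360 nM, compound 2 `O=C(O)C1CCN(c2cccc(OC(F)(F)F)c2)C1` gives 63000 nM, and compound 3 `CNC(=O)C1CCN(c2ccc(Cl)c(C(F)(F)F)c2)C1` gives 1300 nM. Compound 3 thus stands second highest of the three: the nearest number is that of compound 1, lower by a gap beyond the scatter, and the furthest is that of compound 2, higher by a much larger gap, also beyond the scatter. Compound 4 `COCCNC(=O)C1CCN(c2ccc(Cl)c(C(F)(F)F)c2)C1` keeps the rest of compound 3 and differs in one place only: methoxymethyl in place of hydrogen on a saturated chain carbon bound to an amide-type nitrogen. Among the compounds with values here, no pair of measured compounds shows this change, so there is no measured step to set its size by, and the only anchor is the number of compound 3 itself. The step from compound 3 to compound 4 is expected to be small, a 1.2-fold higher number from compound 3 to compound 4 (0.06 log units; within the scatter), with no direction settled beyond the scatter. Compound 4 is therefore estimated at 1500 nM in this assay, within the range 500 nM to 5000 nM.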

Compound 4, half-maximal inhibitory concentration: 3500 nM
The estimate for compound 4 lay 2.3-fold (0.37 log units) below the measured number; the range from low to high includes it.
By their numbers in this assay, from the lowest: compound 1; then compound 3; then compound 4; then compound 2.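

Methoxymethyl in place of hydrogen on a saturated chain carbon bound to an amide-type nitrogen gives a 2.7-fold higher number from compound 3 to compound 4 (0.43 log units; beyond the scatter) in this assay and provides the first measured step in the series. This position therefore responds to the change, although the cost is modest and the larger methylcarbamoyl replacement, (2-methoxyethyl)carbamoyl, keeps measurable inhibition. No measurement shown bears on the reason for this step.

One step cannot separate the effect of the added chain length from that of the ether oxygen, so a plain propyl chain in place of the 2-methoxyethyl group remains the open comparison. Also open, as far as these compounds go, is whether a longer chain, or an amine or a carboxylic acid at the end of the chain, would move the number further or reverse the direction of the step.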